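This account rests on a few compounds, and the source may have more. Where it says the series, first, only, none or still open, it means among the compounds named here.

Within the data shown here, in a functional assay on NB-4 cells (Homo sapiens) for cytotoxicity, read by CCK-8 assay, with a stated time of 24 h (on this read-out lower numbers stand for stronger inhibition and higher numbers for weaker inhibition), compound 1 (`C=CC(=O)N1C(=O)CC(c2ccc(OC)cc2)Sc2ccccc21`) gives 32900 nM and compound 2 (`C=CC(=O)N1C(=O)CCSc2ccccc21`) gives 22400 nM within the scatter of each other, so compound 1 stands level with the only other number. Compound 3 (`C=CC(=O)N1C(=O)CC(c2ccc(-c3ccccc3)cc2)Sc2ccccc21`) carries phenyl in place of methoxy on an aromatic carbon, para to a large group (phenyl in place of methoxy on an aromatic carbon). Among the measured compounds shown here, the one measured step that bears on this (a 1.5-fold lower number from compound 1 to compound 2 (0.17 log units; within the scatter)) puts hydrogen in place of 4-methoxyphenyl on a saturated ring carbon and removes that whole group, so a change inside the group is expected to give no step beyond the scatter in this assay in either direction. For the measured compounds named here, no measured compound carries phenyl at this place, so the expectation stays loose. The estimate amounts to a 1.3-fold lower number from compound 1 to compound 3 (0.10 log units; within the scatter) as the expected step. For compound 3 the expected value is 26000 nM (estimated range 11000 nM to 60000 nM).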

Compound 3, half-maximal inhibitory concentration: 57700 nM
Compound 3: middle estimate off by 2.2-fold (0.35 log units), on the low side; the measured number falls inside the stated range.
By their numbers in this assay, from the lowest: compounds 2, 1 and 3 (each within the scatter of the next, the first and the last beyond it).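

In this assay the exchange of methoxy for phenyl on an aromatic carbon, para to a large group, gives a 1.8-fold higher number from compound 1 to compound 3 (0.24 log units; within the scatter), so a six-membered aromatic ring of carbon only can stand at this place without a step beyond the scatter. Among these compounds, compound 2, without the whole 4-methoxyphenyl group, gives 22400 nM and compound 3 gives 57700 nM as the only two numbers beyond the scatter of each other, which makes the outcome at this place less flat than the first pair showed. Nothing measured here accounts for these numbers.

From the compounds shown here alone, whether an amine or a carboxylic acid on this aromatic carbon would give a step beyond the scatter from compound 1 remains open. Also open, going by these compounds, is whether any group at this place can bring the number below that of compound 2.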